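The source may report more compounds than this note shows. Statements on the series, on what has been measured and on what is new or still open speak of the compounds shown alone.

Measured compounds: compound 1 `Oc1cccc(-c2cc(-c3ccoc3)cc(-c3cccc(O)c3)n2)c1`, compound 2 `Oc1cccc(-c2cc(-c3ccccn3)cc(-c3cccc(O)c3)n2)c1`, compound 3 `Oc1cccc(-c2cc(-c3cccnc3)cc(-c3ccccc3O)n2)c1`.

In a functional assay on HeLa cells (Homo sapiens) for cytotoxicity, read by CCK-8 assay (on this read-out higher numbers stand for weaker inhibition and lower numbers for stronger inhibition), compound 1 gives 4630 nM, compound 2 gives 6500 nM and compound 3 gives 7530 nM. Compound 3 stands highest of the three numbers, yet its gaps to compound 2 and to compound 1 are both within the scatter, so the three read as one level. Going by the values given here, the only measured step, a 1.4-fold higher number from compound 1 to compound 2 (0.15 log units; within the scatter), concerns another group and is itself within the scatter. Compound 4 `Oc1cccc(-c2cc(-c3cccnc3)cc(-c3cccc(O)c3)n2)c1` differs from compound 3 by 3-hydroxyphenyl in place of 2-hydroxyphenyl on an aromatic carbon, on an aromatic carbon next to the ring nitrogen. Among the compounds with values here, no measured step bears directly on this change; compound 2, which also carries 3-hydroxyphenyl there, gives 6500 nM. The expected step is a 1.2-fold lower number from compound 3 to compound 4 (0.06 log units; within the scatter), none beyond the scatter. Compound 4 is estimated at 6500 nM, range 3200 nM to 13000 nM.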

Compound 4, half-maximal inhibitory concentration: > 50000 nM
Compound 4 ended at the assay's limit; the forecaster's own chance of this, stated with the estimate: 5%; at least 7.6-fold (0.88 log units) between middle value and limit.
By their numbers in this assay, from the lowest: compounds 1, 2 and 3 (each within the scatter of the next). At a limit, above all of these: compound 4.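

Compound 4 gives > 50000 nM in this assay, which is a limit of the assay and not a number: the limit of > 50000 nM in this assay, at which 1 of the 4 values shown sits.

On the aromatic carbon next to the ring nitrogen, the hydroxyl placement is not silent: 3-hydroxyphenyl in place of 2-hydroxyphenyl brings an at least 6.6-fold higher number from compound 3 to compound 4 (0.82 log units; beyond the scatter). Yet 3-hydroxyphenyl alone does not account for this, since pyridin-3-yl brings an at least 7.6-fold higher number from compound 2 to compound 4 (0.88 log units; beyond the scatter) against pyridin-2-yl and an at least 10-fold higher number from compound 1 to compound 4 (1.03 log units; beyond the scatter) against furan-3-yl, so among these compounds the weak result goes with the pairing of 3-hydroxyphenyl and pyridin-3-yl.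

Open, on these data alone, is whether this pairing effect extends to 4-hydroxyphenyl at that position, or to an amine or a carboxylic acid in place of the hydroxyl.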